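The source may report more compounds than this note shows. Statements on the series, on what has been measured and on what is new or still open speak of the compounds shown alone.

Measured compounds:
- compound 1, `CCCCC(C)(C)[C@H](O)/C=C/[C@H]1CCC(=O)N1CCSc1nc(C(=O)O)cs1`: 8.4 nM
- compound 2, `COCCCC1([C@H](O)/C=C/[C@H]2COC(=O)N2CCSc2nc(C(=O)O)cs2)CCC1`: 25 nM

Both compounds were tested in an assay on isolated protein for agonist activity at prostaglandin E2 receptor EP3 subtype (Homo sapiens); on this read-out higher numbers stand for an effect only at larger amounts of compound and lower numbers for an effect already at smaller amounts. Of the two, compound 2 stands at the higher number; compound 1 gives the lower value, and the gap between them is larger than the usual scatter of repeated measurements of this kind.

Compound 3, `CC#CCC1([C@H](O)/C=C/[C@H]2COC(=O)N2CCSc2nc(C(=O)O)cs2)CCC1`, is not yet measured. It differs from compound 2 in one place: prop-1-yn-1-yl in place of 2-methoxyethyl on a saturated chain carbon bound to a saturated ring carbon. Going by the values given here, no comparable pair of measured compounds shows what such a change does here, so there is no measured step to lean on. The expectation is that the step from compound 2 to compound 3, a 1.3-fold lower number from compound 2 to compound 3 (0.10 log units; within the scatter), stays within the usual scatter, with no clear direction. On that basis compound 3 is estimated at 20 nM in this assay, within a range from 6 nM to 60 nM.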

Compound 3, half-maximal effective concentration: 18 nM
Compound 3: the middle estimate sits 1.1-fold (0.05 log units) above what was measured; the measured number falls inside the stated range.
By their numbers in this assay, from the lowest: compound 1; then compounds 3 and 2 (each within the scatter of the next).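

In this assay, going by these compounds alone, putting prop-1-yn-1-yl in place of 2-methoxyethyl on a saturated chain carbon bound to a saturated ring carbon gives a 1.4-fold lower number from compound 2 to compound 3 (0.14 log units; within the scatter) and provides the first measured step at this position. The swap removes the only hydrogen-bond acceptor in the leaving group and brings in a triple bond, yet the two compounds cannot be told apart on this read-out, so at least these two groups are tolerated about equally on this core. No measurement available here explains why the two groups read alike. As far as these compounds go, it remains open whether an amine, a carboxylic acid or a longer chain at this position would also stay within the scatter. From the compounds shown here alone, it is also open whether the same swap would read alike on the core of compound 1.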